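A Single Stereocentre Flip Against a Flat Ceiling

The source may hold more compounds than are shown below. What is called first, only, known or untested is meant among the compounds shown, and "the series" means these compounds.

Measured so far in a functional assay on HL-60 cells (Homo sapiens) for cytotoxicity, read by MTT assay, with a stated time of 48 h; a lower number here means a stronger inhibitor, a higher number a weaker inhibitor:
Compound 1 `CCOC(=O)[C@@H]1C[C@@]23CN(C)C[C@@H](CCC4=C2[C@@H]1CC4=O)C31CC[C@](CC)(OC)OC1` gives > 40000 nM.
Compound 2 `CCO[C@@]1(CC)CCC2(CO1)[C@@H]1CCC3=C4[C@H](CC3=O)[C@H](C(=O)OC)C[C@@]42CN(C)C1` gives > 40000 nM.
Compound 3 `CC[C@]1(OC)CCC2(CO1)[C@@H]1CCC3=C4[C@H](CC3=O)[C@H](C(=O)OC)C[C@@]42CN(C)C1` gives > 40000 nM.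

Each of these three values is a limit of this assay, not a measured number; all three share (the limit of > 40000 nM in this assay, at which 3 of the 3 values shown sit). Compound 3 thus stands at the limit, with no exact value. Compound 4 `CC[C@@]1(OC)CCC2(CO1)[C@@H]1CCC3=C4[C@H](CC3=O)[C@H](C(=O)OC)C[C@@]42CN(C)C1` keeps every atom and bond of compound 3 and changes only one point of stereochemistry: the two compounds have the same atoms and bonds; at least one stereo element is drawn with a configuration in one of them and without one in the other: 1 of 6 stereo elements differ; a stereocentre at a saturated ring carbon is drawn R in compound 3 and S in compound 4. The measured steps that reach compound 3 are a step that the two limits leave unreadable from compound 1 to compound 3 and a step that the two limits leave unreadable from compound 2 to compound 3; both ends of each are limits, so neither step shows a size or a direction. For the measured compounds named here, no measured step touches a stereocentre, so there is no basis for expecting a change beyond the scatter. The expected step is a step that the limit leaves unreadable from compound 3 to compound 4. Compound 4 is expected to give 60000 nM, within 20000 nM to 200000 nM.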

Compound 4, half-maximal inhibitory concentration: > 40000 nM
Compound 4 was reported as a limit; the forecaster's own chance of this, stated with the estimate: 85%; the middle value lies beyond the limit too.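

Compound 3 and compound 4 both stand at a limit rather than a measured number, so no step between them can be read: the limit of > 40000 nM in this assay, at which 4 of the 4 values shown sit.

The compounds shown leave open whether the configuration at this stereocentre matters in this assay.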